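Swapping an amine for an acid on the shared core

The source may report more compounds than this note shows. Statements on the series, on what has been measured and on what is new or still open speak of the compounds shown alone.

The compounds here share the core of compound 1, `COc1ccc(-c2nc(CN)sc2-c2ccc(OC)cc2)cc1`, and are judged in a functional assay with Oryctolagus cuniculus as the target; a higher number here means a weaker inhibitor, a lower number a stronger inhibitor. Compound 1 gives only a limit in this assay, > 100 nM, so its strength is known just as a boundary, not as a number. The two companions are no more exact. Compound 2, `COc1ccc(-c2nc(C(=O)N3CCNC(CCO)C3)sc2-c2ccc(OC)cc2)cc1`, carries a larger amide side chain and gives the limit > 1000 nM in this assay. Compound 3, `CCOC(=O)C1=C(C)N=C(C)/C(=C(/O)OCC)C1c1nc(-c2ccc(OC)cc2)c(-c2ccc(OC)cc2)s1`, bears a far bulkier substituent on the core and gives the limit < 100 nM. Among the compounds with values here, one of the three values thus sits at the limit of < 100 nM in this assay, at which 1 of the 3 values shown sits, one at the limit of > 100 nM in this assay, at which 1 of the 3 values shown sits, and one at the limit of > 1000 nM in this assay, at which 1 of the 3 values shown sits, and no step between two measured compounds can be read from them.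

Compound 4, `COc1ccc(-c2nc(CCC(=O)O)sc2-c2ccc(OC)cc2)cc1`, differs from compound 1 by carboxymethyl in place of amino on a saturated chain carbon bound to an aromatic carbon. The amino group leaves and a carboxymethyl group enters, the chain growing from aminomethyl to 2-carboxyethyl.

With only limits to lean on, the step that the limit leaves unreadable from compound 1 to compound 4 is expected to be modest and may well stay within the usual scatter, in no firm direction. Compound 4 is therefore estimated at 300 nM, between 100 nM and 3000 nM.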

Compound 4, half-maximal inhibitory concentration: < 100 nM
Compound 4: no number, only a limit; the forecaster's own chance of this, stated with the estimate: 50%; middle value at least 3.0-fold (0.47 log units) away from the limit.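

In this assay, carboxymethyl in place of amino on a saturated chain carbon bound to an aromatic carbon gives a number no higher from compound 1 to compound 4 (the limit leaves the size open). The size of this step cannot be read because compound 4 sits at a limit and not at a number: the limit of < 100 nM in this assay, at which 2 of the 4 values shown sit. The result still adds something new, as it shows that the amino group of compound 1 is not needed at this place and that a chain ending in a carboxylic acid can stand there with no rise in the number.

The step changes two things at once, the end group and the chain length, so the compounds shown do not tell which of the two matters: a 2-aminoethyl chain would keep the amine on the longer chain, and a carboxylic acid on a shorter chain would keep the acid with less length. From the compounds shown here alone, it also stays open whether the free acid itself counts, which a methyl ester or a primary amide at the same place could test, and how strong compound 4 is in actual numbers.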